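Ester variation on a bicyclic enone: a chloro-phenyl analogue

A few compounds are considered here, and "the series" means these few. Any claim that something is new, unique, unknown or untested is made for them only; others in the source may bear on it.

Measured so far:
Compound 1, `CCCC(=O)O[C@]12C=CC(=O)C[C@H]1OCC2`, in a functional assay on HeLa S3 cells (Homo sapiens) for cytotoxicity; on this read-out higher numbers stand for weaker inhibition and lower numbers for stronger inhibition: 2.7 ug/mL.
Compound 2, `O=C1C=C[C@]2(OC(=O)c3ccccc3)CCO[C@@H]2C1`, in this assay: 1.6 ug/mL.

Within the data shown here, compound 2 carries the lowest of the two numbers so far, but its only neighbour is compound 1, and the step of a 1.7-fold lower number from compound 1 to compound 2 (0.23 log units; within the scatter) lies within the scatter, so no order between the two can be read from these values. That step exchanges the whole acyl group on the carbonyl carbon.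

Compound 3, `O=C1C=C[C@]2(OC(=O)c3cccc(Cl)c3)CCO[C@@H]2C1`, is the next member and is not yet measured. Against compound 2 the change is chloro in place of hydrogen on an aromatic carbon. Among the measured compounds shown here, no measured step bears on a substituent on the phenyl ring; the single step available, a 1.7-fold lower number from compound 1 to compound 2 (0.23 log units; within the scatter), concerns the group on the carbonyl carbon and is itself within the scatter. With nothing pointing in either direction, the expectation is a number close to that of compound 2.

Compound 3 is therefore expected to give about 1.4 ug/mL in this assay, with a range from 0.6 ug/mL to 3.5 ug/mL. The expected step of a 1.1-fold lower number from compound 2 to compound 3 (0.06 log units; within the scatter) is thus one that stays within the scatter.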

Compound 3, half-maximal inhibitory concentration: 1.2 ug/mL
Beside the measured number, compound 3's estimate is 1.2-fold (0.07 log units) above it; low and high end bracket the measured number.
By their numbers in this assay, from the lowest: compounds 3, 2 and 1 (each within the scatter of the next, the first and the last beyond it).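

Among these compounds, the chloro group, on an aromatic carbon of a six-membered aromatic ring of carbon only and meta to a large group, is the first change made on the phenyl ring rather than to the whole acyl group. In this assay this exchange of hydrogen for a single chlorine atom gives a 1.3-fold lower number from compound 2 to compound 3 (0.12 log units; within the scatter) and so does not separate compound 3 from compound 2 on these values. The position therefore accepts a chloro group with no readable effect on the number, though one substituent at one place supports no trend, and nothing among the available data bears on the reason for this result.

Still open, going by these compounds, is whether a methoxy group or an amine on the same aromatic carbon, or a chloro group on another carbon of the phenyl ring, would give a step beyond the scatter. Also open, on these data alone, is how a carboxylic acid on the phenyl ring, or a longer chain on the carbonyl carbon in place of the propyl group of compound 1, would read in this assay on the shared core.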